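This account rests on a few compounds, and the source may have more. Where it says the series, first, only, none or still open, it means among the compounds named here.

Compound 3, `CCCCCCCCCCCCCCCC(=O)Nc1cc2c(cc1F)c(=O)c(C(=O)OCC)cn2CC`, carries the longest acyl chain of the three compounds measured in a functional assay on A549 cells (Homo sapiens) for cytotoxicity, read by MTT assay; on this read-out lower numbers stand for stronger inhibition and higher numbers for weaker inhibition. In that assay compound 3 gives 24300 nM, the second highest number of the three. Compound 1, `CCCCCCCCCCCCCC(=O)Nc1cc2c(cc1F)c(=O)c(C(=O)OCC)cn2CC`, gives 9600 nM, and compound 2, `C=CCCCCCCCCC(=O)Nc1cc2c(cc1F)c(=O)c(C(=O)OCC)cn2CC`, gives 66500 nM. Lengthening the chain of compound 1 gave a 2.5-fold higher number from compound 1 to compound 3 (0.40 log units; beyond the scatter), while shortening it and ending it in a vinyl gave a 6.9-fold higher number from compound 1 to compound 2 (0.84 log units; beyond the scatter); between those two, a 2.7-fold lower number from compound 2 to compound 3 (0.44 log units; beyond the scatter).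

Compound 4, `CCCCCCCCCCCC(=O)Nc1cc2c(cc1F)c(=O)c(C(=O)OCC)cn2CC`, has not yet been measured in this assay. Compared with compound 3 the change is hydrogen in place of butyl on a saturated chain carbon, ten or more bonds along the chain from a carbonyl carbon, so the chain is cut back to a length shorter than that of compound 1. Within the data shown here, the steps that bear on this are the chain-length steps: the step from compound 1 to compound 3 says two extra chain carbons weakened the effect, and the step from compound 1 to compound 2 says a shorter chain, though one ending in a vinyl, weakened it more. Neither step points cleanly to a gain from cutting compound 3 back by four carbons, so little movement beyond the scatter is expected, with the risk leaning toward a weaker effect. For compound 4 the estimate is 28000 nM, with a range from 9000 nM to 75000 nM, meaning an expected 1.2-fold higher number from compound 3 to compound 4 (0.06 log units; within the scatter).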

Compound 4, half-maximal inhibitory concentration in the A549 assay: 10300 nM
Beside the measured number, compound 4's estimate is 2.7-fold (0.43 log units) above it; the measured number falls inside the stated range.
By their numbers in the A549 assay, from the lowest: compounds 1 and 4 (each within the scatter of the next); then compound 3; then compound 2.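

In the A549 assay, taking butyl off a saturated chain carbon gives a 2.4-fold lower number from compound 3 to compound 4 (0.37 log units; beyond the scatter), so the longest chain is not the best one here, and the fully saturated chain also stands clear of the vinyl-ended chain, with a 6.5-fold lower number from compound 2 to compound 4 (0.81 log units; beyond the scatter). In the A549 assay the further cut shows no real separation, with a 1.1-fold higher number from compound 1 to compound 4 (0.03 log units; within the scatter), so among the saturated chains the effect holds level across compound 1 and compound 4 and falls off only at compound 3, while compound 2, with its shorter vinyl-ended chain, goes against any simple rule that shorter is better. In a physicochemical assay (a higher number here means that more compound is needed for the effect, a lower number that less compound is needed), compound 3 gives "not active" (no number reported) and compound 4 gives "not active" (no number reported), so no step can be read there, and nothing measured here accounts for the differences between these chains.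

Still open, from the compounds shown here alone, is whether the level stretch continues with a still shorter saturated chain or ends there. Also open, going by these compounds, is how an amine or a carboxylic acid at the end of the chain, in place of the vinyl, would compare with compound 4.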